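Title: Replacing the nitrobenzylidene group on the shared core

A few compounds are considered here, and "the series" means these few. Any claim that something is new, unique, unknown or untested is made for them only; others in the source may bear on it.

Of the compounds shown here, two have been tested in a functional assay on the whole organism (strain albino) for inhibition, with Rattus norvegicus as the target, read by paw edema, with stated times of 1 h and 3 h, at a dose of 20 mmol/kg by the intraperitoneal route; on this read-out lower numbers stand for a weaker effect and higher numbers for a stronger effect at the one dose given. Compound 1, `N#CC1=C(NCN2CCCC2)N(c2ccccc2)C(=O)N2CCCCC(N3CCCC3)C12`, gives 35.3%. Compound 2, `N#CC1=C(/N=C/c2ccc([N+](=O)[O-])cc2)N(c2ccccc2)C(=O)N2CCCCC(N3CCCC3)C12`, gives 91.7%. For the measured compounds named here, on these two numbers compound 2 stands highest, and the single step that separates them is large: a number 56.4 percentage points higher from compound 1 to compound 2 (beyond the scatter). That step shows that the group on the double-bonded ring carbon of the shared core has a strong hold on the read-out.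

Compound 3, `COC(=O)C(=O)NC1=C(C#N)C2C(N3CCCC3)CCCCN2C(=O)N1c1ccccc1`, has not yet been measured. It differs from compound 2 as follows: a group of 7 heavy atoms (3 carbon, 1 nitrogen, 3 oxygen; no ring) in place of a group of 11 heavy atoms (7 carbon, 2 nitrogen, 2 oxygen; one six-membered aromatic ring of carbon only), on a double-bonded ring carbon

Going by the values given here, the only step that bears on this change is the one from compound 1 to compound 2, and it was large. Compound 3 carries neither the group of compound 1 nor that of compound 2, and the entering group brings back a hydrogen-bond donor, as the group in compound 1 had. A downward step from compound 2 is therefore expected, of uncertain size. The estimate for compound 3 is 55%, within a range of 30% to 85%, which means an expected step of a number 36.7 percentage points lower from compound 2 to compound 3 (beyond the scatter).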

Compound 3, a percentage reported as inhibition, in the whole organism at one dose (the size of the read-out at that dose, not a potency): 88.3%
Compound 3: middle estimate off by 33.3 percentage points, on the low side; measured number outside the range, above it.
By their numbers in this assay, from the lowest: compound 1; then compounds 3 and 2 (each within the scatter of the next).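

In this assay, the change from the group with the aromatic ring to ((methoxycarbonyl)carbonyl)amino gives a number 3.4 percentage points lower from compound 2 to compound 3 (within the scatter), so on the double-bonded ring carbon of the shared core, a six-membered aromatic ring of carbon only is not needed for a read-out at this level at the one dose given. The other new comparison keeps the amine nitrogen and changes only what it carries: (methoxycarbonyl)carbonyl in place of (pyrrolidin-1-yl)methyl gives a number 53 percentage points higher from compound 1 to compound 3 (beyond the scatter), which shows that the hydrogen-bond donor present in both compounds does not by itself set the read-out and that the group on this nitrogen has a strong hold on it. Nothing at hand explains why these groups give these read-outs.

As far as these compounds go, it remains open which part of the (methoxycarbonyl)carbonyl group matters, since a carboxylic acid in place of the methyl ester or a simple acetyl group on the same nitrogen would separate the parts. The single dose also leaves open whether compound 2 and compound 3 would still match at other doses.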